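This account rests on a few compounds, and the source may have more. Where it says the series, first, only, none or still open, it means among the compounds named here.

Compound 1 `CNC1=CC(=O)c2c(cnc(C)c2C)C1=O`: 4100 nM in a functional assay on cells (Homo sapiens) for cytotoxicity, read by propidium iodide staining, with a stated time of 4 days; on this read-out lower numbers stand for stronger inhibition and higher numbers for weaker inhibition
Compound 2 `CNC1=CC(=O)c2cc(C)ncc2C1=O`: 1180 nM in this assay

Within the data shown here, of these two numbers, compound 2 holds the lower one, and the only measured step is a 3.5-fold lower number from compound 1 to compound 2 (0.54 log units; beyond the scatter). Compound 3 `Cc1cc2c(cn1)C(=O)C(NCl)=CC2=O` differs from compound 2 by chloro in place of methyl on an amine nitrogen. Among the measured compounds shown here, the one measured step concerns a different site, so no measured step bears directly on this change; nothing points to a shift beyond the scatter in this assay, and the uncertainty is wide. Compound 3 is therefore expected to give roughly 2000 nM, within a range from 400 nM to 10000 nM. The step this estimate implies is a 1.7-fold higher number from compound 2 to compound 3 (0.23 log units; within the scatter).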

Compound 3, half-maximal inhibitory concentration: 1230 nM
Compound 3: middle estimate off by 1.6-fold (0.21 log units), on the high side; the measured number falls inside the stated range.
By their numbers in this assay, from the lowest: compounds 2 and 3 (each within the scatter of the next); then compound 1.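

The earlier compounds shown here showed only a change at another site. On the amine nitrogen, chloro in place of methyl comes with a 1.0-fold higher number from compound 2 to compound 3 (0.02 log units; within the scatter) in this assay, so this exchange of one heavy atom for another leaves the number within the scatter. Nothing measured here offers an explanation for this result. The compounds shown leave open how this nitrogen would respond to an ethyl group, a benzyl group or an acetyl group, and whether a free amine would give a similar number in this assay.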